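Adding a benzyloxy group to an inactive cytotoxic scaffold

The compounds below may be only part of what the source reports. "The series", "measured", "known", "first", "only" and "open" are said of these compounds alone.

Measured compounds:
- compound 1, `Cc1cc(O)c(C(=O)/C=C/c2ccccc2)c(-c2ccccc2)c1C(=O)/C=C/c1ccccc1`: "not active" (no number reported)
- compound 2, `Cc1cc(O)c(C(=O)/C=C/c2cccc3ccccc23)c(-c2ccccc2)c1C(=O)/C=C/c1cccc2ccccc12`: "not active" (no number reported)
- compound 3, `Cc1cc(O)c(C(=O)/C=C/c2ccc(Br)cc2)c(-c2ccc(Br)cc2)c1C(=O)/C=C/c1ccc(Br)cc1`: 30000 nM

Of the compounds shown here, three sharing one core have been tested in a functional assay on HeLa cells (Homo sapiens) for cytotoxicity, read by MTT assay, with a stated time of 24 h; a higher number here means a weaker inhibitor, a lower number a stronger inhibitor. Compound 1 is recorded in this assay as "not active" (no number reported), so no number stands against it. Compound 2 likewise gives "not active" (no number reported) in this assay, again without a number. Only compound 3 yields a measured value: in this assay compound 3 gives 30000 nM, a weak inhibition. Compound 1 therefore sits among the two entries for which no single number was reported, and the only numerical anchor in the set comes from compound 3.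

The unmeasured compound 4, `Cc1cc(O)c(C(=O)/C=C/c2ccccc2)c(-c2ccc(OCc3ccccc3)cc2)c1C(=O)/C=C/c1ccccc1`, is built from compound 1 by a single change, (benzyloxy in place of hydrogen on an aromatic carbon), on the aromatic ring attached to the core, para to a large group. Among the measured compounds shown here, no measured pair in the set differs at this position, so no step can be quoted for it. Given that compound 1 showed no measurable activity and that the one measured relative, compound 3, reached only 30000 nM, compound 4 is expected to remain a weak inhibitor at best, around 40000 nM, with a range from 10000 nM to 150000 nM, and a real chance that this assay again reports no number for it.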

Compound 4, half-maximal inhibitory concentration: "not active" (no number reported)
Nothing numeric was reported for compound 4; there is nothing to compare the estimate with.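

In this assay compound 1 gives "not active" (no number reported) and compound 4 gives "not active" (no number reported) as well, so no step can be read between these two compounds. No supporting evidence bears on this result. As far as these compounds go, whether the benzyloxy group changes cytotoxicity on the shared core remains open.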